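This account rests on a few compounds, and the source may have more. Where it says the series, first, only, none or still open, it means among the compounds named here.

Working notes on the series in an ADME assay on J774.A1 cells (Mus musculus) for cytotoxicity, read by MTT assay, with a stated time of 48 h; a lower number here means that less compound is tolerated, a higher number that more compound is tolerated: compound 1 (`C/C(=C\c1ccccc1)C(=O)/C=C/c1ccccc1`) gives 34500 nM, compound 2 (`COc1ccc(/C=C/C(=O)/C(C)=C/c2ccccc2)cc1`) gives 51000 nM, and compound 3 (`C/C(=C\c1ccccc1)C(=O)/C=C/c1ccc([N+](=O)[O-])cc1`) gives 26000 nM. Compound 3 thus stands within the scatter of both others. Compound 4 (`C/C(=C\c1ccc([N+](=O)[O-])cc1)C(=O)/C=C/c1ccc([N+](=O)[O-])cc1`) differs from compound 3 by one change: nitro in place of hydrogen on an aromatic carbon, para to a large group. The closest measured precedent is the same exchange, a 1.3-fold lower number from compound 1 to compound 3 (0.12 log units; within the scatter). The methoxy steps, a 1.5-fold higher number from compound 1 to compound 2 (0.17 log units; within the scatter) and a 2.0-fold lower number from compound 2 to compound 3 (0.29 log units; within the scatter), also bear on it. No step beyond the scatter is therefore expected in this assay. The expected step is a 1.2-fold lower number from compound 3 to compound 4 (0.09 log units; within the scatter). Compound 4 is estimated at 21000 nM, with an expected range of 10000 nM to 42000 nM.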

Compound 4, half-maximal cytotoxic concentration: 43000 nM
Beside the measured number, compound 4's estimate is 2.0-fold (0.31 log units) below it, and the stated range ends below it.
By their numbers in this assay, from the lowest: compounds 3, 1, 4 and 2 (each within the scatter of the next).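

Compound 4 is the first shown with a group on this aromatic ring, as the methoxy and the first nitro both sit on the other ring. Nitro in place of hydrogen on an aromatic carbon, para to a large group, gives a 1.7-fold higher number from compound 3 to compound 4 (0.22 log units; within the scatter) in this assay, so this position also takes nitro without a step beyond the scatter. Nothing shown gives a measured reason for the size of this step. As far as these compounds go, whether an amine or a carboxylic acid at this position would stay within the scatter remains open. So does a methoxy here, on this ring, alone or with the nitro on the other ring.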